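Sulfonamide nitrogen swap from compound 1 to compound 4

A few compounds are considered here, and "the series" means these few. Any claim that something is new, unique, unknown or untested is made for them only; others in the source may bear on it.

Measured in a functional assay on UO-31 cells (Homo sapiens) for antiproliferative activity, read by sulforhodamine B assay, with a stated time of 72 h; on this read-out higher numbers stand for weaker inhibition and lower numbers for stronger inhibition:
- compound 1 (`Cc1cc(C)nc(NS(=O)(=O)c2ccc(Nc3nncc4ccccc34)cc2)n1`) gives 3.4 nM
- compound 2 (`C(=C/c1ccccc1)\C(=N\Nc1nncc2ccccc12)c1ccccc1`) gives 3.9 nM
- compound 3 (`O=C1CS/C(=N/Nc2nncc3ccccc23)N1`) gives 25 nM

Compound 1 and compound 2 lie within the scatter of each other. Compound 3 stands beyond the scatter from compound 1, on the side of weaker inhibition, so compound 1 belongs to the low-number pair of this small set.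

Compound 4 (`Cc1cc(NS(=O)(=O)c2ccc(Nc3nncc4ccccc34)cc2)no1`) keeps the core of compound 1 and differs in one place (5-methyl-1,2-oxazol-3-yl in place of 4,6-dimethylpyrimidin-2-yl on a sulfonamide nitrogen). Within the data shown here, no measured pair isolates a change on the sulfonamide nitrogen, so the data give no direct guide to its size. The three measured compounds differ too widely for such a reading. A small step toward a higher number in this assay is expected, most likely within the scatter, with the starting point set by compound 1 at 3.4 nM and a wide range left open. The estimate corresponds to an expected 1.8-fold higher number from compound 1 to compound 4 (0.25 log units; within the scatter) in this read-out. Compound 4 is estimated at 6 nM (expected range 2 nM to 20 nM).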

Compound 4, half-maximal inhibitory concentration: 33 nM
For compound 4 the middle estimate is 5.5-fold (0.74 log units) below the measured one, and the stated range ends below it.
By their numbers in this assay, from the lowest: compounds 1 and 2 (each within the scatter of the next); then compounds 3 and 4 (each within the scatter of the next).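

In this assay, this first change on a sulfonamide nitrogen that can be read as a single step gives a 9.7-fold higher number from compound 1 to compound 4 (0.99 log units; beyond the scatter), so the group at this position matters to the read-out, which the widely differing earlier compounds could not show. The swap of 4,6-dimethylpyrimidin-2-yl for 5-methyl-1,2-oxazol-3-yl leaves the counts of hydrogen-bond donors and acceptors and the net charge unchanged, yet the step lies beyond the scatter, so these counts alone do not set the number in this pair. No measured evidence on hand bears on this step.

Ring size, hetero atoms and methyl substitution all change together in this swap, and which of them carries the step stays open. Values for an unsubstituted pyrimidin-2-yl or a plain phenyl on the same sulfonamide nitrogen would help to separate these changes.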